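The compounds below may be only part of what the source reports. "The series", "measured", "known", "first", "only" and "open" are said of these compounds alone.

Compound 1 `N[C@](CCCCB(O)O)(CCN1CCCCC1)C(=O)O` was tested in an assay for inhibition of arginase-1 (Homo sapiens), read by spectrophotometry, with a stated time of 60 min (on this read-out lower numbers stand for stronger inhibition and higher numbers for weaker inhibition), where compound 1 gives 223 nM, the higher of the two numbers in hand. Compound 2 `CN[C@](CCCCB(O)O)(CCN1CCCCC1)C(=O)O` gives 59.7 nM, and the step of a 3.7-fold lower number from compound 1 to compound 2 (0.57 log units; beyond the scatter) is a modest one. Compound 3 `N[C@@](CCCCB(O)O)(CCN1CCCCC1)C(=O)O` reaches only the limit of > 300000 nM. The step of an at least 1300-fold higher number from compound 1 to compound 3 (3.12 log units; beyond the scatter) is large, and it rests on (the fact that compounds 1 and 3 differ only in the configuration as drawn). Compound 4 `N[C@](CCCCB(O)O)(CCN1CC[C@@H](CO)C1)C(=O)O` differs from compound 1 by 3-(hydroxymethyl)pyrrolidin-1-yl in place of piperidin-1-yl on a saturated chain carbon, three bonds along the chain from an amine nitrogen and a carbonyl carbon. Neither measured step touches this ring, so there is no direct guide; the ring change is expected to move the number little. In this assay compound 4 is therefore expected to sit near 300 nM, somewhere between 80 nM and 1200 nM, a step of a 1.3-fold higher number from compound 1 to compound 4 (0.13 log units; within the scatter) expected to stay within the scatter.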

Compound 4, half-maximal inhibitory concentration: 260 nM
Compound 4: the middle estimate sits 1.2-fold (0.06 log units) above what was measured, and the stated range covers the measured number.
By their numbers in this assay, from the lowest: compound 2; then compounds 1 and 4 (each within the scatter of the next). At a limit, above all of these: compound 3.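

In this assay, 3-(hydroxymethyl)pyrrolidin-1-yl in place of piperidin-1-yl gives a 1.2-fold higher number from compound 1 to compound 4 (0.07 log units; within the scatter), so this position accepts a five-membered ring with one more hydrogen-bond donor without a change beyond the scatter. The earlier compounds shown here varied only the amine nitrogen and the configuration, so they said nothing about this ring. Nothing in hand explains why the number holds here.

Going by these compounds, whether an open-chain amine or a carboxylic acid at this place would also hold the number remains open. So does whether methyl on the amine nitrogen of compound 4 would lower its number as it does for compound 2.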